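This account rests on a few compounds, and the source may have more. Where it says the series, first, only, none or still open, it means among the compounds named here.

Measured so far in a functional assay on OVCAR-5 cells (Homo sapiens) for inhibition, with a stated time of 48 h, tested at 50 uM; a lower number here means less inhibition of growth, a higher number more inhibition of growth at the concentration tested:
- compound 1 `C=C[C@@](C)(/C=C/c1ccc(OC(C)=O)cc1)CCC=C(C)C`: 71%
- compound 2 `C=C[C@@](C)(/C=C/c1ccc(OC(=O)CCCC)cc1)CCC=C(C)C`: 3%

Of these two, compound 2 stands lower, at 3%. Compound 3 `C=C[C@@](C)(/C=C/c1ccc(OC(=O)CCCCC)cc1)CCC=C(C)C` differs from compound 2 by methyl in place of hydrogen on a saturated chain carbon, four bonds along the chain from a carbonyl carbon. Among the compounds with values here, only one measured step bears on this change: a number 68 percentage points lower from compound 1 to compound 2 (beyond the scatter), large and beyond the scatter, with propyl in place of hydrogen on a saturated chain carbon bound to a carbonyl carbon. That single step suggests a low value, but it cannot fix a trend. With compound 2 at 3%, little room remains for a further fall. The expected result is a number 3 percentage points higher from compound 2 to compound 3 (within the scatter), with no change beyond the scatter. For compound 3 the estimate is 6%, with an expected range of 0% to 28%.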

Compound 3, percent growth inhibition at one concentration: 13%
For compound 3 the middle estimate is 7 percentage points below the measured one; low and high end bracket the measured number.
By their numbers in this assay, from the lowest: compounds 2 and 3 (each within the scatter of the next); then compound 1.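

In this assay, methyl in place of hydrogen on a saturated chain carbon, four bonds along the chain from a carbonyl carbon, gives a number 10 percentage points higher from compound 2 to compound 3 (within the scatter), so this added carbon brings no change beyond the scatter. The wider step, with butyl as the added group, gives a number 58 percentage points lower from compound 1 to compound 3 (beyond the scatter), so the large drop seen with propyl also holds with butyl. Nothing at hand explains the drop. From the compounds shown here alone, whether a longer chain stays as low remains open, as does whether an amine on the chain would regain the value of compound 1.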